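Acetylation of the hydroxymethyl on the furan-bearing naphthalene series

A few compounds are considered here, and "the series" means these few. Any claim that something is new, unique, unknown or untested is made for them only; others in the source may bear on it.

Measured compounds:
compound 1 `CCc1cccc2c(OC)c(-c3occ(C)c3CO)ccc12`: 7.1 ug/mL
compound 2 `CCOc1c(-c2occ(C)c2CO)ccc2c(CC)cccc12`: > 10 ug/mL

In a functional assay on KB cells (Homo sapiens) for cytotoxicity, read by MTT assay, with a stated time of 72 h (on this read-out higher numbers stand for an effect only at larger amounts of compound and lower numbers for an effect already at smaller amounts), compound 1 gives 7.1 ug/mL. For compound 2 only a limit of the assay is known, > 10 ug/mL, a limit at which one of the two values sits (the limit of > 10 ug/mL in this assay, at which 1 of the 2 values shown sits); where compound 2 stands on the scale is therefore open-ended upward. For the measured compounds named here, the single measured step, an at least 1.4-fold higher number from compound 1 to compound 2 (0.14 log units; that floor lies within the scatter), is the one comparison available.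

Compound 3 `CCOc1c(-c2occ(C)c2COC(C)=O)ccc2c(CC)cccc12` is not yet measured. It differs from compound 2 by acetyl in place of hydrogen on an oxygen on a saturated carbon, giving an acetoxymethyl where compound 2 carries a hydroxymethyl. Going by the values given here, no measured step concerns this change; the step from compound 1 to compound 2 touches a different position and offers no guide. For compound 3 the expectation is therefore a step that the limit leaves unreadable from compound 2 to compound 3, that is none beyond the scatter, with a high chance that the assay again reports only a limit. Compound 3 is estimated at 15 ug/mL, within 5 ug/mL to 50 ug/mL.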

Compound 3, concentration for half-maximal effect: > 10 ug/mL
Compound 3: only a limit was reported (the forecaster's own chance of this, stated with the estimate: 70%); the middle value is on the limit's open side.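

No step can be read from compound 2 to compound 3 in this assay, as both compounds sit at the same limit: the limit of > 10 ug/mL in this assay, at which 2 of the 3 values shown sit.

The compounds shown leave open where compound 2 and compound 3 stand beyond that limit, and so whether acetoxymethyl in place of hydroxymethyl changes the number at all.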